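This account rests on a few compounds, and the source may have more. Where it says the series, first, only, none or still open, it means among the compounds named here.

Working notes on the series.

The shared core is carried unchanged through compounds 1 and 2; only the aromatic group on the ring nitrogen varies. Compound 1 `CC1(C)[C@H]2CC[C@]1(C)N(Cc1cn(-c3ccccc3C#N)nn1)C(=O)C2` gives 100 nM in a functional assay on A549 cells (Homo sapiens) for inhibition, read by MTT assay, with a stated time of 24 h; a lower number here means a stronger inhibitor, a higher number a weaker inhibitor. Compound 2 `CC1(C)[C@H]2CC[C@]1(C)N(Cc1cn(-c3cccc(Cl)c3)nn1)C(=O)C2` gives 60 nM in this assay. Within the data shown here, of the two numbers measured so far, compound 1 carries the larger one, but the single comparison available, a 1.7-fold lower number from compound 1 to compound 2 (0.22 log units; within the scatter), lies within the scatter, so the two compounds are not separated.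

Compound 3 `COc1ccc(-n2cc(CN3C(=O)C[C@@H]4CC[C@@]3(C)C4(C)C)nn2)cc1` is not yet measured. It differs from compound 1 as follows: 4-methoxyphenyl in place of 2-cyanophenyl on an aromatic nitrogen. Among the measured compounds shown here, the only measured step that bears on this change is the one from compound 1 to compound 2, which also swaps the aromatic group on the ring nitrogen and was within the scatter. No step beyond the scatter is therefore expected in this assay for compound 3.

The estimated value for compound 3 in this assay is 90 nM, with a range from 35 nM to 250 nM. The expected step from compound 1 to compound 3 is a 1.1-fold lower number from compound 1 to compound 3 (0.05 log units; within the scatter).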

Compound 3, half-maximal inhibitory concentration: 50 nM
Estimate against measurement, compound 3: 1.8-fold (0.26 log units) above; the range from low to high includes it.
By their numbers in this assay, from the lowest: compounds 3, 2 and 1 (each within the scatter of the next).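

In this assay, among these compounds, 4-methoxyphenyl in place of 2-cyanophenyl on the aromatic nitrogen gives a 2.0-fold lower number from compound 1 to compound 3 (0.30 log units; within the scatter) and 4-methoxyphenyl in place of 3-chlorophenyl gives a 1.2-fold lower number from compound 2 to compound 3 (0.08 log units; within the scatter), so compound 3 is separated from neither of the earlier compounds. Compound 3 extends the earlier picture to a group that carries oxygen rather than nitrogen or chlorine, and all three groups on this aromatic nitrogen now stand within the scatter of one another, even though the step from the 2-cyanophenyl to the 4-methoxyphenyl group is the largest of the three. Nothing at hand bears on the cause of these small differences.

In the compounds shown, the identity of the group on the phenyl ring and its place on that ring change together, so their separate contributions cannot be read. Also open, going by these compounds, is whether this flat picture would hold for a phenyl ring bearing an amine or a carboxylic acid, or for a saturated cyclohexyl group on the same nitrogen.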